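Chloro for fluoro on the 2,4-difluorobenzyl group

The source may hold more compounds than are shown below. What is called first, only, known or untested is meant among the compounds shown, and "the series" means these compounds.

In a functional assay on MCF cells (Homo sapiens) for antiproliferative activity, with a stated time of 72 h (a lower number here means a stronger inhibitor, a higher number a weaker inhibitor), compound 1 `OC[C@H]1O[C@@H](n2cnc3c(NCc4ccc(Cl)cc4Cl)ncnc32)[C@H](O)[C@@H]1O` gives 127000 nM as its value. Compound 2 `COc1ccc(CNc2ncnc3c2ncn3[C@@H]2O[C@H](CO)[C@@H](O)[C@H]2O)c(OC)c1` shows > 166000 nM which is only a limit. Compound 3 `OC[C@H]1O[C@@H](n2cnc3c(NCc4ccc(F)cc4F)ncnc32)[C@H](O)[C@@H]1O` shows > 166000 nM which is also only a limit, so it has no number of its own. These two stand at the limit of > 166000 nM in this assay, at which 2 of the 3 values shown sit, and no further reading exists for them. Compound 4 `OC[C@H]1O[C@@H](n2cnc3c(NCc4ccc(F)cc4Cl)ncnc32)[C@H](O)[C@@H]1O` differs from compound 3 by chloro in place of fluoro on an aromatic carbon with chloro in place of fluoro on an aromatic carbon, ortho to a large group. The closest evidence is an at least 1.3-fold higher number from compound 1 to compound 3 (0.11 log units; that floor lies within the scatter) and, with another group, an at least 1.3-fold higher number from compound 1 to compound 2 (0.11 log units; that floor lies within the scatter) as a second reference. Neither step exceeds the scatter, so the expected change is an at least 1.1-fold lower number from compound 3 to compound 4 (0.04 log units; that floor lies within the scatter) and nothing beyond the scatter is expected. Compound 4 is estimated at 150000 nM with an expected range from 90000 nM to 240000 nM in this assay.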

Compound 4, half-maximal inhibitory concentration: > 166000 nM
Compound 4: only a limit was reported; the forecaster's own chance of this, stated with the estimate: 55%; middle value at least 1.1-fold (0.04 log units) away from the limit.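

In this assay compound 4 is reported only as a limit, > 166000 nM, so chloro in this place, with the fluoro group kept, gives no reading of its own. Within the data shown here, the one step that can be read is an at least 1.3-fold higher number from compound 1 to compound 4 (0.11 log units; that floor lies within the scatter), a floor and nothing more. The steps to compound 4 from compound 2 and compound 3 cannot be read, because limits stand at both ends: the limit of > 166000 nM in this assay, at which 3 of the 4 values shown sit.

From the compounds shown here alone, whether a bromo or a methyl group in this place would give a number remains open. So does the true size of the fluoro-for-chloro step.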